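The source may hold more compounds than are shown below. What is called first, only, known or untested is meant among the compounds shown, and "the series" means these compounds.

Measured so far in an ADME assay on NHDF cells (Homo sapiens) for cytotoxicity, read by MTT assay, with a stated time of 72 h; on this read-out lower numbers stand for stronger inhibition and higher numbers for weaker inhibition
- compound 1 `COc1cccc(/C=C2\CCC/C(=C\c3ccccc3Cl)C2=O)c1OC` gives 44200 nM
- compound 2 `COc1cccc(/C=C2\CCC/C(=C\c3ccc(Br)cc3)C2=O)c1OC` gives 21400 nM
- compound 3 `COc1ccc(/C=C2\CCC/C(=C\c3ccc(Br)cc3)C2=O)cc1OC` gives 13100 nM

Compound 3 and compound 2 sit within the scatter of each other, and both give lower numbers than compound 1. Compound 4 `COc1ccc(/C=C2\CCC/C(=C\c3ccc(Cl)c(Cl)c3)C2=O)cc1OC` has not yet been measured. It carries 3,4-dichlorophenyl in place of 4-bromophenyl on a double-bonded chain carbon bound to a double-bonded ring carbon. Among the measured compounds shown here, only one measured step touches this place: a 2.1-fold lower number from compound 1 to compound 2 (0.32 log units; beyond the scatter) was modest, and it put 4-bromophenyl in place of 2-chlorophenyl. With that single guide, a 1.2-fold lower number from compound 3 to compound 4 (0.08 log units; within the scatter) in this assay is expected to stay within the scatter, with no clear direction. For compound 4 the estimated value is 11000 nM with an expected range (5000 nM to 24000 nM).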

Compound 4, half-maximal inhibitory concentration: 10100 nM
Beside the measured number, compound 4's estimate is 1.1-fold (0.04 log units) above it; measured number inside the range.
By their numbers in this assay, from the lowest: compounds 4, 3 and 2 (each within the scatter of the next, the first and the last beyond it); then compound 1.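

In this assay, 3,4-dichlorophenyl in place of 4-bromophenyl on a double-bonded chain carbon bound to a double-bonded ring carbon gives a 1.3-fold lower number from compound 3 to compound 4 (0.11 log units; within the scatter), so the two groups cannot be told apart here. This position therefore accepts two chlorine atoms on the phenyl ring in place of one bromine with no clear shift in the number. Nothing available explains this likeness. Every group shown at this place is a halogen-bearing phenyl ring. From the compounds shown here alone, whether a phenyl ring carrying an amine or a carboxylic acid would move the number beyond the scatter stays open.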